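Stereochemical inversion in a phenyl-tetrahydropyran amine series

A few compounds are considered here, and "the series" means these few. Any claim that something is new, unique, unknown or untested is made for them only; others in the source may bear on it.

Measured so far:
- compound 1, `c1ccc([C@@H]2CCC[C@H](CCNCC3CCCCC3)O2)cc1`: 36 nM
- compound 2, `c1ccc([C@@H]2CCC[C@H](CCN3CCCC3)O2)cc1`: 170 nM
- compound 3, `c1ccc([C@H]2CCC[C@@H](CCN3CCN(c4ccccc4)CC3)O2)cc1`: 131 nM

All three values come from an assay on membranes from liver for displacement of a labelled ligand from Sigma intracellular receptor 2 (Rattus norvegicus), read by scintillation counting; on this read-out higher numbers stand for weaker inhibition and lower numbers for stronger inhibition. Compound 3 stands second highest of the three; its nearest neighbour is compound 2, whose number lies within the scatter of it, so no order between these two can be read. Compound 1 sits at a clearly lower number, beyond the scatter, so compound 1 is the only one of the three that separates from compound 3.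

Compound 4, `c1ccc([C@@H]2CCC[C@H](CCN3CCN(c4ccccc4)CC3)O2)cc1`, has not been measured. Its relation to compound 3 is this: the two compounds have the same atoms and bonds and differ only in configuration as drawn: 2 of 2 stereo elements differ (all stereocentres are inverted: mirror images); a stereocentre at a saturated ring carbon is drawn R in compound 3 and S in compound 4; a stereocentre at a saturated ring carbon is drawn S in compound 3 and R in compound 4. For the measured compounds named here, no measured pair differs only in configuration, so the size of such a step is unknown here; compounds 1 and 2 carry the same drawn configuration as compound 4 but differ from compound 3 in the amine part as well, and give no clean comparison.

For a mirror-image pair in this assay a step in either direction is possible, most likely modest. The estimate places compound 4 near compound 3, with a step of a 1.2-fold lower number from compound 3 to compound 4 (0.08 log units; within the scatter) expected to be small and not clearly beyond the scatter. Compound 4 is estimated at 110 nM, within a range from 30 nM to 400 nM.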

Compound 4, inhibition constant: 161 nM
The estimate for compound 4 lay 1.5-fold (0.17 log units) below the measured number; measured number inside the range.
By their numbers in this assay, from the lowest: compound 1; then compounds 3, 4 and 2 (each within the scatter of the next).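

In this assay, the series now has its first clean reading of configuration: a 1.2-fold higher number from compound 3 to compound 4 (0.09 log units; within the scatter), so inverting both stereocentres produces no resolved difference for this amine part. The step isolates configuration alone: the fact that compounds 3 and 4 differ only in the configuration as drawn. Compound 4 also shares its drawn configuration with compounds 1 and 2, so the amine parts can now be compared at one configuration: compound 1 gives 36 nM, compound 2 gives 170 nM and compound 4 gives 161 nM, with only compound 1 separating from the other two, whose values lie within the scatter of each other.

Whether inversion is equally silent for the amine parts of compounds 1 and 2 remains open, as does the effect of inverting only one of the two stereocentres, since the shown pair changes both together. Also open, going by these compounds, is whether the separation seen for compound 1 would extend to a morpholine as the amine part, or to a longer chain leading to the amine.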